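The source may hold more compounds than are shown below. What is called first, only, known or untested is meant among the compounds shown, and "the series" means these compounds.

Compound 1 `O=S(=O)(NCc1ccc(F)cc1)c1ccc2c(c1)nc(C1CC1)n2Cc1ccccc1` gives 1900 nM in an assay on isolated protein for inhibition of Gonadotropin-releasing hormone receptor (Homo sapiens); a higher number here means a weaker inhibitor, a lower number a stronger inhibitor.
Compound 2 `CCCc1nc2cc(S(=O)(=O)NCc3ccc(F)cc3)ccc2n1Cc1ccccc1` reaches only the limit of > 10000 nM in this assay.

Going by the values given here, compound 2 thus stands at the limit of > 10000 nM in this assay, at which 1 of the 2 values shown sits, and the one measured step, an at least 5.2-fold higher number from compound 1 to compound 2 (0.72 log units; beyond the scatter), leads to it. Compound 3 `CC(C)(C)NC(=O)CCCc1nc2cc(S(=O)(=O)NCc3ccc(F)cc3)ccc2n1Cc1ccccc1` differs from compound 2 by (tert-butyl)carbamoyl in place of hydrogen on a saturated chain carbon, three bonds along the chain from an aromatic carbon. Among the compounds with values here, no measured step touches such a group on the chain, so that step is only a loose guide, and compound 3 is expected to remain near the limit. Compound 3 is therefore estimated at 10000 nM, between 3000 nM and 30000 nM, a step of a number no higher from compound 2 to compound 3 (the limit leaves the size open) that is expected not to go beyond the scatter.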

Compound 3, half-maximal inhibitory concentration: 400 nM
Compound 3: the middle estimate sits 25-fold (1.40 log units) above what was measured, outside the stated range (below it).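

Placed on the saturated chain carbon, three bonds along the chain from an aromatic carbon, (tert-butyl)carbamoyl gives an at least 25-fold lower number from compound 2 to compound 3 (1.39 log units; beyond the scatter) in this assay, so a substituted chain at this position need not leave the compound weak. The size of that step is only a bound, since compound 2 stands at a limit: the limit of > 10000 nM in this assay, at which 1 of the 3 values shown sits. The 3-((tert-butyl)carbamoyl)propyl group also outdoes cyclopropyl, with a 4.8-fold lower number from compound 1 to compound 3 (0.68 log units; beyond the scatter).

The compounds shown leave open whether the tert-butyl group or the amide carries this change. Going by these compounds, whether a carboxylic acid, an amine or a longer chain would serve equally at this place also remains open.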